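This account rests on a few compounds, and the source may have more. Where it says the series, first, only, none or still open, it means among the compounds named here.

Compound 1 `Nc1ncnc2c1ncn2[C@@H]1O[C@H](CN(CCCCC(=O)O)Cc2cccc(C(=O)O)c2)[C@@H](O)[C@H]1O` gives in an assay on cells for inhibition of Nicotinamide N-methyltransferase (Homo sapiens), with stated times of 10 min and 30 min (on this read-out higher numbers stand for weaker inhibition and lower numbers for stronger inhibition), only a limit of the assay, > 250000 nM. Compound 2 `Nc1ncnc2c1ncn2[C@@H]1O[C@H](CN(CCCC(=O)O)Cc2ccc3ccccc3c2)[C@@H](O)[C@H]1O` likewise returns only a limit in this assay, > 250000 nM. Going by the values given here, both values therefore sit at the same limit (the limit of > 250000 nM in this assay, at which 2 of the 2 values shown sit), and no step between measured compounds can be read from them. Compound 3 `Nc1ncnc2c1ncn2[C@@H]1O[C@H](CN(CCCCC(=O)O)Cc2ccc3ccccc3c2)[C@@H](O)[C@H]1O` differs from compound 2 by carboxymethyl in place of carboxy on a saturated chain carbon, three bonds along the chain from an amine nitrogen. With both measured values at the limit, no direction can be taken from them, and the expected step of a number no higher from compound 2 to compound 3 (the limit leaves the size open) is nothing beyond the scatter. Compound 3 is estimated at 250000 nM in this assay, within 80000 nM to 1000000 nM, most likely again reported only as a limit.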

Compound 3, half-maximal inhibitory concentration: > 250000 nM
Compound 3 was reported as a limit (the forecaster's own chance of this, stated with the estimate: 85%); the middle value sits exactly at the limit.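

In this assay compound 3 gives > 250000 nM, a limit of the assay, so no step from compound 3 to compound 1 or compound 2 can be read: the limit of > 250000 nM in this assay, at which 3 of the 3 values shown sit.

Whether carboxymethyl or naphthalen-2-yl changes shift inhibition at all remains open, with no compound shown yet giving a value inside the assay's range.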